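The source may report more compounds than this note shows. Statements on the series, on what has been measured and on what is new or still open speak of the compounds shown alone.

Compound 1 `COC1=C(C)C(=O)/C(=C(O)/C=C/c2ccc(C)cc2)C(=O)C1(C)C` is the starting point of this step. Among the compounds with values here, in a functional assay on PC-3 cells (Homo sapiens) for cytotoxicity (a lower number here means that less compound is needed, a higher number that more compound is needed for the effect), compound 1 gives 8.2 ug/mL, the lowest of the two numbers known so far, though its nearest neighbour, compound 2 `COC1=C(C)C(=O)/C(=C(O)/C=C/c2ccccc2C)C(=O)C1(C)C`, gives 9 ug/mL, and the step of a 1.1-fold higher number from compound 1 to compound 2 (0.04 log units; within the scatter) is within the scatter, so no order between the two can be claimed. The unmeasured compound 3 `COC1=C(C)C(=O)/C(=C(O)/C=C/c2nccs2)C(=O)C1(C)C` differs from compound 1 in one place: 1,3-thiazol-2-yl in place of 4-methylphenyl on a double-bonded chain carbon bound to a double-bonded chain carbon. Within the data shown here, the only measured step, from compound 1 to compound 2, moves a methyl from one position on the phenyl ring to another and left the number essentially unchanged; it bears only loosely on a swap of the whole ring for a five-membered ring with two hetero atoms, for which no measured step exists. The estimate therefore rests on little beyond the shared core. Compound 3 is expected to give 11 ug/mL, between 4.5 ug/mL and 27 ug/mL, so that the expected step of a 1.3-fold higher number from compound 1 to compound 3 (0.13 log units; within the scatter) is modest and uncertain in direction.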

Compound 3, concentration for half-maximal effect: 10.8 ug/mL
The estimate for compound 3 lay 1.0-fold (0.01 log units) above the measured number; measured number inside the range.
By their numbers in this assay, from the lowest: compounds 1, 2 and 3 (each within the scatter of the next).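

In this assay, the earlier compounds had shown only a methyl moved around the phenyl ring, whereas compound 3 exchanges the whole ring for 1,3-thiazol-2-yl, a five-membered aromatic ring with 2 hetero atoms, and gives the step of a 1.3-fold higher number from compound 1 to compound 3 (0.12 log units; within the scatter) and also the step of a 1.2-fold higher number from compound 2 to compound 3 (0.08 log units; within the scatter) at the same place. Even this larger change of ring therefore allows no order among compounds 1, 2 and 3 at this position on a double-bonded chain carbon. Nothing available explains why these numbers lie so close.

Open, as far as these compounds go, is whether a group of another kind at this place, such as an amine, a carboxylic acid or a longer alkyl chain, would give a step beyond the scatter. Also open, from the compounds shown here alone, is how a change to the shared core, identical in all three compounds, would read.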